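The source may hold more compounds than are shown below. What is called first, only, known or untested is meant among the compounds shown, and "the series" means these compounds.

Measured compounds:
Compound 1 `N#CC1=C(N)Oc2c(N)cc3nc4ccccc4nc3c2C12C(=O)N(Cc1cnnn1-c1ccccc1Cl)c1ccccc12` in an ADME assay on HUVEC cells (Homo sapiens) for antiproliferative activity, read by MTT assay, with a stated time of 48 h (on this read-out lower numbers stand for stronger inhibition and higher numbers for weaker inhibition), gives > 50000 nM, which is a limit of the assay and not a number.
Compound 2 `N#CC1=C(N)Oc2c(N)cc3nc4ccccc4nc3c2C12C(=O)N(Cc1cnnn1-c1cccc(Br)c1)c1ccccc12` gives > 50000 nM, likewise a limit rather than a number.
Compound 3 `CCc1cccc(CC)c1-n1nncc1CN1C(=O)C2(C(C#N)=C(N)Oc3c(N)cc4nc5ccccc5nc4c32)c2ccccc21` gives > 50000 nM, again only a limit.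

Among the measured compounds shown here, compound 3 thus stands where every value so far sits, at the limit of > 50000 nM in this assay, at which 3 of the 3 values shown sit. The three compounds share one core and differ only in the aryl group on an aromatic nitrogen, yet the steps a step that the two limits leave unreadable from compound 1 to compound 2, a step that the two limits leave unreadable from compound 1 to compound 3 and a step that the two limits leave unreadable from compound 2 to compound 3 give no readable size, so no change of this aryl group has yet moved a value off the limit.

Compound 4 `COc1cc(-n2nncc2CN2C(=O)C3(C(C#N)=C(N)Oc4c(N)cc5nc6ccccc6nc5c43)c3ccccc32)c(OC)cc1Cl` continues this series with 4-chloro-2,5-dimethoxyphenyl in place of 2,6-diethylphenyl on an aromatic nitrogen. The three measured steps are the ones that bear on it, and none of them was readable. The step that the limit leaves unreadable from compound 3 to compound 4 is therefore expected to be no movement beyond the scatter, with the value most probably again reported as a limit. Compound 4 is expected to give about 70000 nM in this assay, within a range from 20000 nM to 250000 nM.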

Compound 4, half-maximal inhibitory concentration: > 50000 nM
Compound 4: no number, only a limit; the forecaster's own chance of this, stated with the estimate: 85%; the middle value does not contradict the limit.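

Compound 4, like compound 1, compound 2 and compound 3, gives only a limit and not a number, so no step among these four compounds can be read: the limit of > 50000 nM in this assay, at which 4 of the 4 values shown sit.

Going by these compounds, it remains open whether any aryl group at this place on the shared core can bring a value in this assay off the limit.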